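Adding a Second Chloro to Compound 2's Core

The compounds below may be only part of what the source reports. "The series", "measured", "known", "first", "only" and "open" are said of these compounds alone.

The data compare two compounds in a functional assay on PC-3 cells (Homo sapiens) for cytotoxicity, read by sulforhodamine B assay, with a stated time of 48 h; on this read-out lower numbers stand for stronger inhibition of growth and higher numbers for weaker inhibition of growth. Compound 1 `Nc1nc(Cl)c2ncn(Cc3ccc(CCl)cc3)c2n1` gives 7410 nM, and compound 2 `ClCc1cccc(Cn2cnc3c(Cl)ncnc32)c1` gives 4160 nM. Compound 2 has the lower of the two numbers, but its gap to compound 1 lies within the scatter, so neither can be called stronger. Compound 3 `ClCc1cccc(Cn2cnc3c(Cl)nc(Cl)nc32)c1` differs from compound 2 by chloro in place of hydrogen on an aromatic carbon. Among the compounds with values here, no measured pair shows this change, so the step is expected to be small, with no clear direction beyond the scatter. Compound 3 is estimated at 3000 nM, between 1200 nM and 7500 nM, a step of a 1.4-fold lower number from compound 2 to compound 3 (0.14 log units; within the scatter).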

Compound 3, concentration for 50% growth inhibition: 2390 nM
Compound 3: the middle estimate sits 1.3-fold (0.10 log units) above what was measured; the measured number falls inside the stated range.
By their numbers in this assay, from the lowest: compounds 3, 2 and 1 (each within the scatter of the next, the first and the last beyond it).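

On the aromatic carbon between two ring nitrogen atoms, chloro in place of hydrogen gives a 1.7-fold lower number from compound 2 to compound 3 (0.24 log units; within the scatter) in this assay. Within the data shown here, this is the first single-place comparison, and it shows that this change does not clearly separate the two compounds in growth inhibition. Nothing measured here accounts for the size of this step. Still open, on these data alone, is whether a larger group on this same carbon, such as methoxy or a carboxylic acid, would give a step beyond the scatter.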